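From Cyclopropyl to Cycloheptyl on a Shared Core

This account rests on a few compounds, and the source may have more. Where it says the series, first, only, none or still open, it means among the compounds named here.

Compound 1 (`OC[C@H]1O[C@@H](n2cnc3c(NC4CCCC4)nc(NC4CCCC4)nc32)[C@H](O)[C@@H]1O`) gives > 500000 nM in an ADME assay on HEK-293T cells (Homo sapiens) for cytotoxicity, read by resazurin assay, with a stated time of 16 h (on this read-out higher numbers stand for weaker inhibition and lower numbers for stronger inhibition), as a limit of the assay and not a number. Compound 2 (`OC[C@H]1O[C@@H](n2cnc3c(NC4CC4)nc(NC4CCCC4)nc32)[C@H](O)[C@@H]1O`) gives > 500000 nM as a limit as well, so it has no exact number to stand on. The record so far is short, with the limit of > 500000 nM in this assay, at which 2 of the 2 values shown sit, as the whole picture.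

Compound 3 (`OC[C@H]1O[C@@H](n2cnc3c(NC4CCCCCC4)nc(NC4CCCC4)nc32)[C@H](O)[C@@H]1O`) keeps the shared core and differs from compound 2 in one place: cycloheptyl in place of cyclopropyl on a nitrogen on an aromatic ring. For the measured compounds named here, the one measured step of this kind is a step that the two limits leave unreadable from compound 1 to compound 2 and it swaps cyclopentyl for cyclopropyl on such a nitrogen, so it offers no size to carry over. No step beyond the usual scatter is therefore expected in this assay and compound 3 may well return only a limit too. The expected change is a number no higher from compound 2 to compound 3 (the limit leaves the size open) as an estimate only. For compound 3 the estimated value is 500000 nM with an expected range from 200000 nM to 1000000 nM on this read-out.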

Compound 3, half-maximal inhibitory concentration: > 500000 nM
Compound 3 was reported as a limit; the forecaster's own chance of this, stated with the estimate: 75%; the middle value sits exactly at the limit.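

In this assay compound 3 gives > 500000 nM, a limit of the assay and not a number. The steps among compound 1, compound 2 and compound 3 cannot be read, as all three share one reading: the limit of > 500000 nM in this assay, at which 3 of the 3 values shown sit. The compounds shown leave open whether cyclopropyl, cyclopentyl and cycloheptyl on this nitrogen differ in cytotoxicity at all.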